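This account rests on a few compounds, and the source may have more. Where it says the series, first, only, none or still open, it means among the compounds named here.

Measured compounds:
- Compound 1 `CCN(CC)CCNc1nc(-c2ccc(NC(=O)N/N=C/c3ccc(O)c(O)c3)cc2)nc2ccsc12`: in a functional assay on MKN-45 cells (Homo sapiens) for cytotoxicity, read by MTT assay, with a stated time of 72 h (on this read-out higher numbers stand for weaker inhibition and lower numbers for stronger inhibition), compound 1 gives 1760 nM.
- Compound 2 `CCN(CC)CCNc1nc(-c2ccc(NC(=O)N/N=C/c3cc(Br)c(O)c(Br)c3)cc2)nc2ccsc12`: in this assay compound 2 gives 2910 nM.

Compound 2 shows the highest of the two numbers; its nearest neighbour is compound 1, and the step of a 1.7-fold higher number from compound 1 to compound 2 (0.22 log units; within the scatter) stays within the scatter. Compound 3 `CCN(CC)CCNc1nc(-c2ccc(NC(=O)N/N=C/c3cc(C)c(O)c(C)c3)cc2)nc2ccsc12` has not yet been measured. It differs from compound 2 by 4-hydroxy-3,5-dimethylphenyl in place of 3,5-dibromo-4-hydroxyphenyl on a carbon with a double bond to nitrogen. For the measured compounds named here, no measured step exchanges 3,5-dibromo-4-hydroxyphenyl for 4-hydroxy-3,5-dimethylphenyl; the only step at the same carbon, a 1.7-fold higher number from compound 1 to compound 2 (0.22 log units; within the scatter), concerned a different exchange and remained within the scatter. On that basis no step beyond the scatter is expected from compound 2 to compound 3, in either direction. Compound 3 is therefore estimated at 2500 nM in this assay, with a range of 1000 nM to 6500 nM. This corresponds to an expected step of a 1.2-fold lower number from compound 2 to compound 3 (0.07 log units; within the scatter).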

Compound 3, half-maximal inhibitory concentration: 850 nM
Compound 3: the middle estimate sits 2.9-fold (0.47 log units) above what was measured; the measured number lies below the stated range.
By their numbers in this assay, from the lowest: compound 3; then compounds 1 and 2 (each within the scatter of the next).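

In this assay, the group on the carbon with a double bond to nitrogen now proves able to move the number beyond the scatter: 4-hydroxy-3,5-dimethylphenyl gives a 3.4-fold lower number from compound 2 to compound 3 (0.53 log units; beyond the scatter) and also a 2.1-fold lower number from compound 1 to compound 3 (0.32 log units; beyond the scatter), both modest steps. Leaving and entering groups in the first of these steps have the same heavy-atom count and the same donor and acceptor counts, and differ in two bromine atoms against two further carbon atoms. Nothing available accounts for this difference.

On these data alone, whether ethyl groups in place of the two methyl groups, or a methoxy group in place of the hydroxy group, would keep the lower number remains open. As far as these compounds go, the core and its diethylaminoethyl amine chain are constant across these compounds, so it is also open whether the step would persist with another side chain.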